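A Methoxybenzyl Analogue in the Antiproliferative Series

This account rests on a few compounds, and the source may have more. Where it says the series, first, only, none or still open, it means among the compounds named here.

Compound 1 `O=C(NCc1cn(Cc2ccc(F)cc2)nn1)c1cn(-c2ccccc2)nc1-c1ccc(Cl)cc1`: 1990 nM
Compound 2 `O=C(NCc1cn(Cc2ccc(Cl)cc2)nn1)c1cn(-c2ccccc2)nc1-c1ccc(Cl)cc1`: 410 nM
Compound 3 `O=C(NCc1cn(Cc2ccc(C(F)(F)F)cc2)nn1)c1cn(-c2ccccc2)nc1-c1ccc(Cl)cc1`: 1100 nM

All three compounds were tested in a functional assay on MIA PaCa-2 cells (Homo sapiens) for antiproliferative activity, read by sulforhodamine B assay, with a stated time of 48 h (on this read-out higher numbers stand for weaker inhibition of growth and lower numbers for stronger inhibition of growth), and share one core, differing only in the group on the benzyl ring. Compound 3 stands between the others: its number lies within the scatter of compound 1 (a 1.8-fold lower number from compound 1 to compound 3 (0.26 log units; within the scatter)) but clearly apart from compound 2 (a 2.7-fold higher number from compound 2 to compound 3 (0.43 log units; beyond the scatter)). The largest step in the set is a 4.9-fold lower number from compound 1 to compound 2 (0.69 log units; beyond the scatter).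

Compound 4 `COc1ccc(Cn2cc(CNC(=O)c3cn(-c4ccccc4)nc3-c3ccc(Cl)cc3)nn2)cc1` carries the change (methoxy in place of trifluoromethyl on an aromatic carbon). Among the compounds with values here, no measured step involves a methoxy group, so none bears directly on it; the three measured steps only show that changing the group at this position shifts the number by modest amounts in either direction. The expectation is therefore a step of no more than modest size, most likely within the scatter, in an uncertain direction.

Compound 4 is estimated at 1200 nM, with a range from 400 nM to 3500 nM. The expected step is a 1.1-fold higher number from compound 3 to compound 4 (0.04 log units; within the scatter).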

Compound 4, concentration for 50% growth inhibition: 290 nM
Estimate against measurement, compound 4: 4.1-fold (0.62 log units) above; the whole stated range lies above it.
By their numbers in this assay, from the lowest: compounds 4 and 2 (each within the scatter of the next); then compounds 3 and 1 (each within the scatter of the next).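

In this assay, the position proves able to give a clear gain with a group other than chloro: methoxy in place of trifluoromethyl on the aromatic carbon gives a step beyond the scatter (a 3.8-fold lower number from compound 3 to compound 4 (0.58 log units; beyond the scatter)), and methoxy in place of fluoro gives the largest step in the set (a 6.9-fold lower number from compound 1 to compound 4 (0.84 log units; beyond the scatter)). Against chloro, the step is within the scatter (a 1.4-fold lower number from compound 2 to compound 4 (0.15 log units; within the scatter)), so the four compounds fall into two pairs, compound 2 with compound 4 and compound 1 with compound 3. Nothing shown gives a reason why methoxy and chloro fall together here.

The compounds shown leave open whether a hydroxyl, an ethoxy chain or an amine at this place would join compound 2 and compound 4. They also leave open whether the methoxy step holds on any other core.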